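Methylating the ring amine of compound 2

The compounds below may be only part of what the source reports. "The series", "measured", "known", "first", "only" and "open" are said of these compounds alone.

In a functional assay on SF-268 cells (Homo sapiens) for cytotoxicity, read by MTT assay, with a stated time of 3 days (a higher number here means a weaker inhibitor, a lower number a stronger inhibitor), compound 1 (`CCNc1nc(SCc2nc3ccccc3[nH]2)nc(-c2ccccc2)c1C#N`) gives 7.35 nM as its reading, while compound 2 (`N#Cc1c(-c2ccccc2)nc(SCc2nc3ccccc3[nH]2)nc1N1CCNCC1`) gives 20000 nM and so holds the higher of the two numbers. Within the data shown here, the one measured step is large: a 2700-fold higher number from compound 1 to compound 2 (3.43 log units; beyond the scatter) when piperazin-1-yl replaces ethylamino. Compound 3 (`CN1CCN(c2nc(SCc3nc4ccccc4[nH]3)nc(-c3ccccc3)c2C#N)CC1`) differs from compound 2 only by methyl in place of hydrogen on an amine nitrogen in a ring. The measured step exchanged a whole group, so it offers no direct measure of this smaller change and serves only as a loose upper guide to its size. In this assay a far smaller step is therefore expected, estimated as a 1.8-fold lower number from compound 2 to compound 3 (0.26 log units; within the scatter) and possibly no larger than the scatter. For compound 3 the expected value is 11000 nM with a wide estimated range (2000 nM to 40000 nM).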

Compound 3, half-maximal inhibitory concentration: 6.9 nM
The estimate for compound 3 lay 1600-fold (3.20 log units) above the measured number; the measured number lies below the stated range.
By their numbers in this assay, from the lowest: compounds 3 and 1 (each within the scatter of the next); then compound 2.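

In this assay, the amine nitrogen in the ring proves highly sensitive to substitution, since a single methyl in place of hydrogen gives a 2900-fold lower number from compound 2 to compound 3 (3.46 log units; beyond the scatter). The large loss seen with piperazin-1-yl therefore does not carry over to 4-methylpiperazin-1-yl, and exchanging ethylamino for this methylated ring gives a 1.1-fold lower number from compound 1 to compound 3 (0.03 log units; within the scatter), which lies within the scatter. Nothing available here gives a reason for so large an effect from one added carbon.

As far as these compounds go, whether an ethyl group, a longer chain or an acetyl group on that nitrogen would read like compound 3 or like compound 2 remains open. From the compounds shown here alone, it is also open whether the ring nitrogen must be an amine at all, as a morpholine ring, with oxygen at that place, would test.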